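Ethoxy for methylamino on a chlorophenyl biguanide

This account rests on a few compounds, and the source may have more. Where it says the series, first, only, none or still open, it means among the compounds named here.

The series is measured in a physicochemical assay for lipophilicity, in phosphate buffer, measured as octanol-water partition, at pH 11.5; a higher number here means a more lipophilic compound, a lower number a more polar compound. Compound 1 `CCCCCCCCCCNC(=N)NC(=N)Nc1ccc(Cl)cc1` gives 6.13 in this assay, the highest of the three numbers. Compound 3 `CCCS(=O)(=O)c1ccc(NC(=N)NC(=N)NCCCCCCNC(=N)NC(=N)Nc2ccc(S(=O)(=O)CCC)cc2)cc1` gives 2.1. Compound 2 `CNC(=N)NC(=N)Nc1ccc(Cl)cc1` gives 1.58, the lowest of the three; its nearest neighbour is compound 3, which lies higher by a gap beyond the scatter, and compound 1 lies far higher still, also beyond the scatter. No two of these three compounds differ in only one place, so none of the gaps between them is attached to a single structural step.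

Compound 4 `CCOC(=N)NC(=N)Nc1ccc(Cl)cc1` has not yet been measured in this assay. It differs from compound 2 in one place: ethoxy in place of methylamino on a carbon with a double bond to nitrogen. The change removes a hydrogen-bond donor and brings in a hydrogen-bond acceptor and one more carbon, while the shared core of compound 2 is kept.

Going by the values given here, with no measured step of this kind among the three compounds, the expectation rests on compound 2 alone at 1.58. A small step upward, of a size at or a little beyond the scatter, is expected from compound 2 to compound 4, a number 0.52 log units higher from compound 2 to compound 4 (beyond the scatter). Compound 4 is therefore estimated at 2.1 in this assay, with a range from 1.5 to 2.8.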

Compound 4, partition coefficient: 2.32
Compound 4: the middle estimate sits 0.22 log units below what was measured, within the range that was stated.
By their numbers in this assay, from the lowest: compound 2; then compounds 3 and 4 (each within the scatter of the next); then compound 1.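

Going by these compounds alone, the swap gives the first step that can be tied to one structural change: in this assay, ethoxy in place of methylamino on a carbon with a double bond to nitrogen gives a number 0.74 log units higher from compound 2 to compound 4 (beyond the scatter). This shows that the number responds to a change at this position by a modest amount that stands clear of the scatter, which the three earlier compounds, none differing in only one place, could not show. The hydrogen-bond donors, the hydrogen-bond acceptors and the heavy atoms all change together in this one step, and nothing at hand separates their shares or gives a cause for its size.

From the compounds shown here alone, it stays open whether other groups at this place, such as methoxy, propoxy or dimethylamino, would give a smaller or a larger step than ethoxy does. Going by these compounds, it is also open whether the same swap would give a step of similar size with a nitrile or a methoxy group in place of the chlorine on the shared core.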